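Ester chain length on a shared dioxide core

This account rests on a few compounds, and the source may have more. Where it says the series, first, only, none or still open, it means among the compounds named here.

Three compounds share one core and differ in the ester group or in the groups on the fused ring. Compound 1 `COC(=O)c1c(C(F)(F)F)[n+]([O-])c2ccc(C(F)(F)F)cc2[n+]1[O-]` in an ADME assay on J774 cells (Mus musculus) for cytotoxicity, read by MTT assay, with a stated time of 48 h (a higher number here means a weaker inhibitor, a lower number a stronger inhibitor), gives 4000 nM. Compound 2 `CCOC(=O)c1c(C(F)(F)F)[n+]([O-])c2ccc(C(F)(F)F)cc2[n+]1[O-]` in this assay gives 4200 nM. Compound 3 `CCOC(=O)c1c(C(F)(F)F)[n+]([O-])c2cc(C)c(C)cc2[n+]1[O-]` in this assay gives 4000 nM. The step of a 1.1-fold lower number from compound 2 to compound 1 (0.02 log units; within the scatter) is the change (hydrogen in place of methyl on a saturated chain carbon bound to an oxygen next to a carbonyl group). The difference between the core of compound 3 and the core of compound 2 is not broken down here; their two values lie within the scatter of each other.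

Compound 4 `COC(=O)c1c(C(F)(F)F)[n+]([O-])c2cc(C)c(C)cc2[n+]1[O-]` is not yet measured. It differs from compound 3 by hydrogen in place of methyl on a saturated chain carbon bound to an oxygen next to a carbonyl group, the same change that leads from compound 2 to compound 1. Because a 1.1-fold lower number from compound 2 to compound 1 (0.02 log units; within the scatter) stayed within the scatter, the step of no change at the digits printed from compound 3 to compound 4 (within the scatter) is expected to stay within the scatter as well. Compound 4 is therefore estimated at 4000 nM in this assay, with a likely range from 2500 nM to 6500 nM.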

Compound 4, half-maximal inhibitory concentration: 4000 nM
Compound 4: the middle estimate sits on the measured number at the digits printed; the range from low to high includes it.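

Swapping the ethoxycarbonyl group for the methoxycarbonyl group on the core of compound 3 gives no change at the digits printed from compound 3 to compound 4 (within the scatter) in this assay. Set beside the earlier step, the change reads alike on both cores: the same change on two cores in this assay, a 1.1-fold lower number (0.02 log units; within the scatter) from compound 2 to compound 1 and no change at the digits printed (within the scatter) from compound 3 to compound 4, 1.1-fold (0.02 log units) apart, within the scatter of two such steps. So in these two pairs the ethoxy to methoxy swap carries from one core to the other with no effect that can be told from assay noise, but two pairs cannot show that this holds on every core in the series, and a real effect smaller than the scatter would stay hidden.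

The compounds shown carry only these two short esters, which leaves open how a longer chain such as butyl, or a carboxylic acid or an amide in the place of the ester, would read in this assay. Going by these compounds, it also remains open whether the swap would read the same on a core with an amine or a chlorine on the fused ring.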